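The compounds below may be only part of what the source reports. "The series", "measured", "known", "first", "only" and "open" are said of these compounds alone.

The measured compounds:

Compound 1, `COc1ccc(-c2nc3cc(/C(C)=N/NC(N)=S)ccc3[nH]2)cc1`, in an ADME assay on Vero cells (Chlorocebus sabaeus) for cytotoxicity, read by MTT assay, with a stated time of 96 h (a lower number here means that less compound is tolerated, a higher number that more compound is tolerated), gives > 100000 nM, which is a limit of the assay rather than a number.
Compound 2, `COc1ccc(-c2nc3cc(/C(C)=N/NC(N)=S)ccc3[nH]2)c(OC)c1`, in this assay gives > 100000 nM, again a limit of the assay.
Compound 3, `COc1ccc(-c2nc3cc(/C(C)=N/NC(N)=O)ccc3n2C2CCCCC2)cc1`, has no result in this assay: "not determined" (no result reported).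

Compound 1 and compound 2 differ by one change, (methoxy in place of hydrogen on an aromatic carbon), and the step that the two limits leave unreadable from compound 1 to compound 2 cannot be read because both values sit at the limit of > 100000 nM in this assay, at which 2 of the 3 values shown sit. Compound 3 and compound 4, `COc1ccc(-c2nc3cc(/C(C)=N/NC(N)=O)ccc3n2C2CCCCC2)c(OC)c1`, differ by the same change, (methoxy in place of hydrogen on an aromatic carbon); the two "place" descriptions agree word for word, so it is the same change made on a different core. How the core of compound 3 differs from the core of compound 1 is not broken down here.

Going by the values given here, for compound 4 in this assay the only guide is that the same change made from compound 1 to compound 2 left both compounds at the limit of > 100000 nM in this assay, at which 2 of the 3 values shown sit, so compound 4 is expected to give 100000 nM, most likely reported as a limit again, with a range from 50000 nM to 200000 nM.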

Compound 4, half-maximal cytotoxic concentration: 20000 nM
Compound 4: middle estimate off by 5.0-fold (0.70 log units), on the high side, and the stated range ends above it.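

In this assay, going by these compounds alone, compound 4 gives 20000 nM, but compound 3 has no number to set against it, so no new step from compound 3 to compound 4 can be read. The compounds shown leave open what methoxy in place of hydrogen does to the result in this assay on the core of compound 3.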